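Swapping the Chain End of Compound 1: What to Expect

The compounds below may be only part of what the source reports. "The series", "measured", "known", "first", "only" and "open" are said of these compounds alone.

Measured so far:
compound 1, `CCC/N=C(/NC#N)NCCCCn1nc(-c2ccccc2)ccc1=O` — in a functional assay on the whole organism (stomach) with Rattus norvegicus as the target (on this read-out higher numbers stand for an effect only at larger amounts of compound and lower numbers for an effect already at smaller amounts), compound 1 gives > 100 mg/kg
compound 2, `C/N=C(/NC#N)NCCCCn1nc(C)ccc1=O` — compound 2 gives > 100 mg/kg
compound 3, `O=c1ccc(-c2ccccc2)nn1CCCC/N=C(\S)Nc1ccc(F)cc1` — compound 3 gives > 100 mg/kg

This figure of compound 3 is a limit of the assay, not a number. The same holds for compound 2. It holds for compound 1 as well. Compound 1 therefore stands where every value sits: at the limit of > 100 mg/kg in this assay, at which 3 of the 3 values shown sit. Among the measured compounds shown here, no two measured compounds differ in a single place, so no measured step shows how any change moves the dose.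

Compound 4, `C=CCNC(=S)NCCCCn1nc(-c2ccccc2)ccc1=O`, is not yet measured. Against compound 1 it differs in one place: a group of 6 heavy atoms (4 carbon, 1 nitrogen, 1 sulfur; no ring) in place of a group of 8 heavy atoms (5 carbon, 3 nitrogen; no ring), on an amine nitrogen. With only limits known, no step beyond the scatter is expected, and the step that the limit leaves unreadable from compound 1 to compound 4 is estimated accordingly. Compound 4 is expected near 150 mg/kg, within 40 mg/kg to 600 mg/kg, most likely again reported only as a limit.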

Compound 4, dose for half-maximal effect: > 100 mg/kg
Compound 4: a limit, no number (the forecaster's own chance of this, stated with the estimate: 75%); the middle value is on the limit's open side.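

In this assay compound 4 gives > 100 mg/kg, a limit and not a number. Among the compounds shown here, compound 1 is also only a limit, and no step between compound 1 and compound 4 can be read. Still open is whether any change to these compounds gives a dose readable as a number: the limit of > 100 mg/kg in this assay, at which 4 of the 4 values shown sit.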